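This account rests on a few compounds, and the source may have more. Where it says the series, first, only, none or still open, it means among the compounds named here.

Measured compounds:
- compound 1 `Cn1c(=O)c(=O)n(C2CCCC2)c2nc(N/N=C/c3cc(C(F)(F)F)c(O)c(C(F)(F)F)c3)ncc21`: 17700 nM
- compound 2 `Cc1cc(C)c(/C=N/Nc2ncc3c(n2)n(C2CCCC2)c(=O)c(=O)n3C)c(C)c1`: 13900 nM

Both compounds share the same core and differ only in the aromatic ring hung on the hydrazone carbon. In a functional assay on PC-3 cells (Homo sapiens) for antiproliferative activity, read by MTT assay (on this read-out higher numbers stand for weaker inhibition and lower numbers for stronger inhibition), compound 1 gives 17700 nM, and in this assay compound 2 gives 13900 nM. The two numbers lie within the usual scatter of each other, so the data do not separate compound 2 from compound 1; both are weak inhibitors on this read-out.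

Compound 3 `Cn1c(=O)c(=O)n(C2CCCC2)c2nc(N/N=C/c3ccccc3Cl)ncc21` is the next compound, and it has not yet been measured. It differs from compound 2 in one place: 2-chlorophenyl in place of 2,4,6-trimethylphenyl on a carbon with a double bond to nitrogen. For the measured compounds named here, no measured pair shows what such a swap does here, so the expectation rests on the two numbers alone. Since the two measured rings, one bearing trifluoromethyl and hydroxyl groups and one bearing methyl groups, give numbers within the scatter of each other, a third substituted phenyl ring is expected to give a change from compound 2 to compound 3 of a 1.1-fold higher number from compound 2 to compound 3 (0.03 log units; within the scatter), meaning no step beyond the scatter. Compound 3 is therefore estimated at 15000 nM in this assay, with a range from 5000 nM to 45000 nM.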

Compound 3, half-maximal inhibitory concentration: 16300 nM
Beside the measured number, compound 3's estimate is 1.1-fold (0.04 log units) below it; the measured number falls inside the stated range.
By their numbers in this assay, from the lowest: compounds 2, 3 and 1 (each within the scatter of the next).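

In this assay, putting 2-chlorophenyl in place of 2,4,6-trimethylphenyl on a carbon with a double bond to nitrogen gives a 1.2-fold higher number from compound 2 to compound 3 (0.07 log units; within the scatter). For the compounds shown here, the earlier compounds offered no step between close relatives, so this is the only direct reading of a single change at this position, and it shows that the number stays within the usual scatter of repeated measurements. That holds even though the ring loses its three methyl groups, gains a chlorine and goes from 9 heavy atoms to 7, and no measurement shown offers an explanation for this outcome.

Every compound shown carries a substituted phenyl ring at this position, so it remains open what an unsubstituted phenyl, a phenyl bearing an amine or a carboxylic acid, or a longer chain in place of the ring would do to the number. From the compounds shown here alone, the shared core is also the same throughout, so it remains open whether a change there would shift the number beyond the scatter.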